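Moving the allyloxy group: notes on HaCaT toxicity

A few compounds are considered here, and "the series" means these few. Any claim that something is new, unique, unknown or untested is made for them only; others in the source may bear on it.

Compound 1 `O=C1CC(N2C(=O)CSC2=S)C(=O)N1c1ccc(O)cc1`: > 100000 nM (a limit)
Compound 2 `C=CCOc1ccccc1/C=C1\SC(=S)N(C2CC(=O)N(c3ccc(Cl)cc3)C2=O)C1=O`: > 100000 nM (a limit)

Both entries come from a toxicity assay on HaCaT cells (Homo sapiens) for inhibition, read by MTT assay, with a stated time of 72 h (on this read-out higher numbers stand for weaker inhibition of growth and lower numbers for stronger inhibition of growth), and neither is a number, so the two compounds cannot be placed in any order. In this assay compound 2 gives > 100000 nM, which is a limit of the assay. Compound 2 therefore stands at the limit of > 100000 nM in this assay, at which 2 of the 2 values shown sit. For the measured compounds named here, no measured step between compounds differing in one place is available.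

Compound 3 `C=CCOc1cccc(/C=C2\SC(=S)N(C3CC(=O)N(c4ccc(Cl)cc4)C3=O)C2=O)c1` is still unmeasured. It carries 3-(allyloxy)phenyl in place of 2-(allyloxy)phenyl on a double-bonded chain carbon bound to a double-bonded ring carbon. The two compounds have the same atoms, joined differently.

The expectation rests on compound 2 alone, at > 100000 nM, itself a limit. The expected change a step that the limit leaves unreadable from compound 2 to compound 3 lies within the scatter, with no direction favoured. The most likely outcome in this assay is that only a limit is reported again. For compound 3 the estimated value is 120000 nM, with an expected range of 60000 nM to 200000 nM.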

Compound 3, concentration for 50% growth inhibition: > 100000 nM
Compound 3 gave a limit, no number; the forecaster's own chance of this, stated with the estimate: 85%; the middle value does not contradict the limit.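

In this assay compound 3 gives > 100000 nM, which is a limit and not a number. Compound 2 gives > 100000 nM, also a limit, so no step can be read from compound 2 to compound 3. The compounds shown leave open whether 3-(allyloxy)phenyl in place of 2-(allyloxy)phenyl changes growth inhibition at all.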